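The source may report more compounds than this note shows. Statements on the series, on what has been measured and on what is new or still open speak of the compounds shown alone.

Of the compounds shown here, three of one shared core have been measured in a functional assay on CHO cells with adenosine receptor A1 (Homo sapiens) as the target, read by cAMP accumulation and immunoassay, with a stated time of 6 min, tested at 0.1 uM; a higher number here means a weaker effect of the compound at the concentration tested, a lower number a stronger effect. Compound 1 `CC(C)N1CCN(Cc2csc(N)c2C(=O)c2ccc(Cl)cc2)CC1` gives 3.6% in this assay. Compound 2 `Nc1scc(CN2CCN(c3ccc(F)cc3Cl)CC2)c1C(=O)c1ccc(Cl)cc1` gives -6.2%. Compound 3 `Nc1scc(CN2CCN(c3ccc([N+](=O)[O-])cc3)CC2)c1C(=O)c1ccc(Cl)cc1` gives -13%, the lowest of the three numbers, though its gap to compound 2 is within the scatter; only its gap to compound 1 is beyond it, and that step, a number 16.6 percentage points lower from compound 1 to compound 3 (beyond the scatter), was modest.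

Compound 4 `Nc1scc(CN2CCN(c3ccc(Cl)c(C(F)(F)F)c3)CC2)c1C(=O)c1ccc(Cl)cc1` has not yet been measured. It differs from compound 3 in one place: 4-chloro-3-(trifluoromethyl)phenyl in place of 4-nitrophenyl on an amine nitrogen in a ring. Among the measured compounds shown here, the steps that bear on this are those that also swap the group on that ring nitrogen: a number 9.8 percentage points lower from compound 1 to compound 2 (within the scatter), a number 16.6 percentage points lower from compound 1 to compound 3 (beyond the scatter) and a number 6.8 percentage points lower from compound 2 to compound 3 (within the scatter). Exchanging one aryl group for another, as between compound 2 and compound 3, moved the number by less than the scatter. A step of similar size, none beyond the scatter, is therefore expected in this assay: a number 5 percentage points higher from compound 3 to compound 4 (within the scatter). Compound 4 is estimated to give -8%, within a range from -25% to 9%.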

Compound 4, a percentage reported as activity, at one concentration (the size of the read-out at that concentration, not a potency): -12%
The estimate for compound 4 lay 4 percentage points above the measured number; the measured number falls inside the stated range.
By their numbers in this assay, from the lowest: compounds 3, 4, 2 and 1 (each within the scatter of the next, the first and the last beyond it).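

Replacing 4-nitrophenyl with 4-chloro-3-(trifluoromethyl)phenyl exchanges the nitrogen and oxygen atoms of the leaving group for fluorine and chlorine, yet this assay shows only a number 1 percentage points higher from compound 3 to compound 4 (within the scatter), and the comparison with the other aryl group gives a number 5.8 percentage points lower from compound 2 to compound 4 (within the scatter), so the aryl groups on this ring nitrogen cannot be told apart here. Against the isopropyl group, the new aryl group gives a number 15.6 percentage points lower from compound 1 to compound 4 (beyond the scatter), which matches the earlier result for 4-nitrophenyl, while 2-chloro-4-fluorophenyl goes against any general aryl-over-isopropyl pattern with a number 9.8 percentage points lower from compound 1 to compound 2 (within the scatter). No measurement available here explains these numbers.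

As far as these compounds go, it remains open what a benzyl group, a pyridine ring or a longer alkyl chain on this nitrogen would give. From the compounds shown here alone, because each number comes from a single concentration, the compounds' potencies also remain open.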